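From Cyclohexyl to 4-Chlorophenyl on the Ring Nitrogen

The source may report more compounds than this note shows. Statements on the series, on what has been measured and on what is new or still open speak of the compounds shown alone.

Compound 1 `O=C1COc2ccc(-c3cnc(Cl)c(NS(=O)(=O)c4ccc(F)cc4)c3)cc2N1C1CCCCC1` offers little to build on. In a functional assay on HepG2 cells (Homo sapiens) for antiproliferative activity, read by MTT assay, with a stated time of 72 h (on this read-out higher numbers stand for weaker inhibition and lower numbers for stronger inhibition), compound 1 gives > 40000 nM, which is a limit and not a number. Compound 2 `COc1ncc(-c2ccc3c(c2)N(C2CCCCC2)C(=O)CO3)cc1NS(=O)(=O)c1ccc(F)cc1` gives > 40000 nM, which is also a limit. Compound 3 `CC(C)N1C(=O)COc2ccc(-c3cccc(NS(=O)(=O)c4ccc(F)cc4)c3)cc21` gives > 40000 nM, again a limit. Compound 1 therefore has no measured number of its own, and all three compounds share one reading: the limit of > 40000 nM in this assay, at which 3 of the 3 values shown sit.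

Compound 4 `O=C1COc2ccc(-c3cnc(Cl)c(NS(=O)(=O)c4ccc(F)cc4)c3)cc2N1c1ccc(Cl)cc1` keeps the core of compound 1 and carries 4-chlorophenyl in place of cyclohexyl on an amide-type nitrogen in a ring. For the measured compounds named here, only one measured step connects compounds that differ in one place: a step that the two limits leave unreadable from compound 1 to compound 2. That step is methoxy in place of chloro on an aromatic carbon, so it does not touch the group that changes here, and its size cannot be read. Going by the values given here, no measured step shows what a change on this nitrogen does in this assay.

The step expected here, a number no higher from compound 1 to compound 4 (the limit leaves the size open), is estimated to stay within the usual scatter, with no direction favoured. Another limit would be the likeliest report. For compound 4 the estimated value is 40000 nM, with an expected range from 15000 nM to 60000 nM.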

Compound 4, half-maximal inhibitory concentration: 33900 nM
The estimate for compound 4 lay 1.2-fold (0.07 log units) above the measured number, and the stated range covers the measured number.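

On the amide-type nitrogen in a ring, 4-chlorophenyl in place of cyclohexyl gives an at least 1.1-fold lower number from compound 1 to compound 4 (0.07 log units; that floor lies within the scatter) in this assay. With this change, the core of compound 1 yields a measured number instead of a limit, and compound 4 is the only compound shown to do so: the limit of > 40000 nM in this assay, at which 3 of the 4 values shown sit. The floor of the step lies within the scatter, so the result shows that this position can give a readable value in this assay, but it does not establish that 4-chlorophenyl is better than cyclohexyl by any definite amount.

Compound 1 has only a limit, which leaves the true size of this step open, and the step with methoxy in place of chloro on an aromatic carbon cannot be read at all. The compounds shown also leave open what an unsubstituted phenyl, or a phenyl carrying a carboxylic acid or an amine, would give on this nitrogen, and whether any such group would move the value in this assay beyond the scatter.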